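Acetamido Replaces Butoxycarbonyl on a Weak Lipase Inhibitor

The source may report more compounds than this note shows. Statements on the series, on what has been measured and on what is new or still open speak of the compounds shown alone.

Compound 1, `CCOc1ccc(-c2cccc(S(=O)(=O)NC)c2)cc1`: 200000 nM
Compound 2, `CCOc1ccc(-c2ccccc2)cc1`: > 200000 nM (a limit)
Compound 3, `CCCCOC(=O)c1cccc(-c2ccc(OCC)cc2)c1`: 100000 nM

All three were tested in an assay on COS-7 cells for inhibition of patatin-like phospholipase domain-containing protein 2 (Mus musculus); a higher number here means a weaker inhibitor, a lower number a stronger inhibitor. Of the two numbers recorded, compound 3 gives the lower one, and its nearest neighbour is reached by a 2.0-fold lower number from compound 1 to compound 3 (0.30 log units; within the scatter), so the two cannot be told apart. For compound 2 the value is a limit of this assay, not a number, and the result for compound 2 sits at the limit of > 200000 nM in this assay, at which 1 of the 3 values shown sits. The step of an at least 2.0-fold lower number from compound 2 to compound 3 (0.30 log units; that floor lies within the scatter) therefore has only a floor, and that floor lies within the scatter.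

The next compound, compound 4 `CCOc1ccc(-c2cccc(NC(C)=O)c2)cc1`, differs from compound 3 in one place: acetamido in place of butoxycarbonyl on an aromatic carbon. Within the data shown here, the steps that bear on this change are the two that end at compound 3. Among the measured compounds shown here, both the swap from methylsulfamoyl and the swap from hydrogen to butoxycarbonyl left the numbers within or at the edge of the scatter, so every group tried at this position so far has given a very weak inhibitor. On that basis compound 4 is expected to stay in the same range, with a 1.5-fold higher number from compound 3 to compound 4 (0.18 log units; within the scatter) being no more than the scatter. The estimate for compound 4 in this assay is 150000 nM, between 60000 nM and 300000 nM.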

Compound 4, half-maximal inhibitory concentration: 200000 nM
Compound 4: the middle estimate sits 1.3-fold (0.12 log units) below what was measured; the range from low to high includes it.
By their numbers in this assay, from the lowest: compounds 3, 1 and 4 (each within the scatter of the next).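

Swapping butoxycarbonyl for acetamido removes a chain and adds a hydrogen-bond donor, yet in this assay this change gives a 2.0-fold higher number from compound 3 to compound 4 (0.30 log units; within the scatter). Replacing methylsulfamoyl with acetamido at the same aromatic carbon gives no change at the digits printed from compound 1 to compound 4 (within the scatter), so three quite different groups at this position now give numbers that cannot be told apart, and this small set shows no sign that the number depends on which of these three groups sits there. For compound 2 the value is a limit of the assay and not a number. The step of a number no higher from compound 2 to compound 4 (the limit leaves the size open) cannot be read because of that limit: the limit of > 200000 nM in this assay, at which 1 of the 4 values shown sits.

On these data alone, what stays open is whether any group at this position can move the number beyond the scatter, for example an amine, a carboxylic acid, or a longer chain in place of the methyl end of the acetamido group. Whether changes elsewhere on the shared core would do more than changes at this position also remains unanswered.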